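A few compounds are considered here, and "the series" means these few. Any claim that something is new, unique, unknown or untested is made for them only; others in the source may bear on it.

Working notes on the series. Going by the values given here, compound 3 `COc1ccc(S(=O)(=O)N2CCc3cccc(-c4ccc(N)cc4)c32)cc1` stands highest of the three numbers so far in a functional assay on KB cells (Homo sapiens) for inhibition, with a stated time of 72 h (on this read-out higher numbers stand for weaker inhibition and lower numbers for stronger inhibition), giving 249 nM. Compound 1 `COc1ccc(S(=O)(=O)N2CCc3cccc(-c4cccnc4)c32)cc1` gives 95.9 nM in this assay, and compound 2 `COc1ccc(S(=O)(=O)N2CCc3cccc(-c4ccncc4)c32)cc1` gives 96 nM; the two differ by a 1.0-fold higher number from compound 1 to compound 2 (0.00 log units; within the scatter). Against them compound 3 rises by a 2.6-fold higher number from compound 1 to compound 3 (0.41 log units; beyond the scatter) and by a 2.6-fold higher number from compound 2 to compound 3 (0.41 log units; beyond the scatter).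

Compound 4 `COc1ccc(S(=O)(=O)N2CCc3cccc(-c4ccco4)c32)cc1` differs from compound 3 by furan-2-yl in place of 4-aminophenyl on an aromatic carbon. Among the compounds with values here, no measured step covers this exchange; the two pyridyl steps only show that a ring bearing an acceptor without a donor has given the lower numbers. Compound 4 is therefore expected to move by a 1.4-fold lower number from compound 3 to compound 4 (0.14 log units; within the scatter), a shift no larger than modest toward the pyridyl level. The estimate for compound 4 in this assay is 180 nM, within 60 nM to 600 nM.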

Compound 4, half-maximal inhibitory concentration: 82 nM
Estimate against measurement, compound 4: 2.2-fold (0.34 log units) above; the range from low to high includes it.
By their numbers in this assay, from the lowest: compounds 4, 1 and 2 (each within the scatter of the next); then compound 3.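

Furan-2-yl shows that this place on the shared core also takes a five-membered aromatic ring, with a 3.0-fold lower number from compound 3 to compound 4 (0.48 log units; beyond the scatter) and with a 1.2-fold lower number from compound 2 to compound 4 (0.07 log units; within the scatter) and a 1.2-fold lower number from compound 1 to compound 4 (0.07 log units; within the scatter) against the pyridyl rings. Among these four compounds only compound 3, with 4-aminophenyl, stands apart, and the other three aryl rings give no separable numbers. No evidence at hand explains this result.

On these data alone, whether the amine or the six-membered carbon ring goes with the higher number of compound 3 stays open. A plain phenyl or a thiophene at this place would test that.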